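This account rests on a few compounds, and the source may have more. Where it says the series, first, only, none or still open, it means among the compounds named here.

Working notes on the aryl-amine series.

Three compounds share one core and differ only in the aryl group on the amine nitrogen. Compound 1 is `C=C1[C@@H](OC(C)=O)C[C@@H]2[C@](C)(CO[Si](C)(C)C(C)(C)C)[C@H](OC(C)=O)CC[C@@]2(C)[C@@H]1C[C@@H](Nc1cccc(F)c1)C1=CCOC1=O` and in a functional assay on MCF7 cells (Homo sapiens) for cytotoxicity, read by sulforhodamine B assay (a higher number here means a weaker inhibitor, a lower number a stronger inhibitor), compound 1 gives 3820 nM. Compound 2 is `C=C1[C@@H](OC(C)=O)C[C@@H]2[C@](C)(CO[Si](C)(C)C(C)(C)C)[C@H](OC(C)=O)CC[C@@]2(C)[C@@H]1C[C@@H](Nc1cccc2ccccc12)C1=CCOC1=O` and in this assay compound 2 gives 5770 nM. Compound 3 is `C=C1[C@@H](OC(C)=O)C[C@@H]2[C@](C)(CO[Si](C)(C)C(C)(C)C)[C@H](OC(C)=O)CC[C@@]2(C)[C@@H]1C[C@@H](Nc1ccc(OC)c(OC)c1)C1=CCOC1=O` and in this assay compound 3 gives 4310 nM. All three numbers lie together: a 1.5-fold higher number from compound 1 to compound 2 (0.18 log units; within the scatter), a 1.1-fold higher number from compound 1 to compound 3 (0.05 log units; within the scatter) and a 1.3-fold lower number from compound 2 to compound 3 (0.13 log units; within the scatter). Compound 3 thus sits inside the same band as compounds 1 and 2, with no separation from either that exceeds the scatter.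

Compound 4 is `C=C1[C@@H](OC(C)=O)C[C@@H]2[C@](C)(CO[Si](C)(C)C(C)(C)C)[C@H](OC(C)=O)CC[C@@]2(C)[C@@H]1C[C@@H](Nc1ccc(O)cc1)C1=CCOC1=O`. Its difference from compound 3 is 4-hydroxyphenyl in place of 3,4-dimethoxyphenyl on an amine nitrogen. The three measured steps are the relevant comparisons, since each of them also exchanges the aryl group on the same amine nitrogen, and none of them moved the number beyond the scatter. Among the measured compounds shown here, no measured step involves a hydroxyphenyl group, so the hydrogen-bond donor that enters has no precedent here. On the evidence of the three steps, no step beyond the scatter is expected for this assay from compound 3 to compound 4, and the estimated step is a 1.0-fold lower number from compound 3 to compound 4 (0.00 log units; within the scatter). Compound 4 is therefore expected to give about 4300 nM in this assay, within a range of 2000 nM to 9000 nM.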

Compound 4, half-maximal inhibitory concentration: 5220 nM
Beside the measured number, compound 4's estimate is 1.2-fold (0.08 log units) below it; measured number inside the range.
By their numbers in this assay, from the lowest: compounds 1, 3, 4 and 2 (each within the scatter of the next).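

In this assay the 4-hydroxyphenyl group falls in the same band as the other aryl groups, with all three new steps inside the scatter: a 1.2-fold higher number from compound 3 to compound 4 (0.08 log units; within the scatter); a 1.1-fold lower number from compound 2 to compound 4 (0.04 log units; within the scatter); and a 1.4-fold higher number from compound 1 to compound 4 (0.14 log units; within the scatter). Of the four aryl groups on this amine nitrogen, 4-hydroxyphenyl alone carries a hydrogen-bond donor, and its entry produces no separation from the three groups that lack one. The position therefore tolerates, in this assay, both that donor and the exchange of 3,4-dimethoxyphenyl for the smaller 4-hydroxyphenyl, and no measured evidence is available to explain why the numbers stay together.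

Still open is whether any group at this position can move the number beyond the scatter: a carboxylic acid or a primary amine on the aromatic ring, or a saturated alkyl chain on the amine nitrogen in place of the aryl group, has no counterpart among these compounds. Also open, going by these compounds, is whether the same flat response to the aryl group would hold with a change elsewhere on the shared core, which stays constant across all four compounds.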